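The source may hold more compounds than are shown below. What is called first, only, known or untested is meant among the compounds shown, and "the series" means these compounds.

Working notes on the series.

Compound 3 `COc1cc(C(c2ccc(O)c(OC)c2)[C@H](CC(C)C)C(C)C)ccc1O` gives 9600 nM in a functional assay on HL-60 cells (Homo sapiens) for cytotoxicity, read by WST assay, with a stated time of 48 h; a lower number here means a stronger inhibitor, a higher number a weaker inhibitor. For the measured compounds named here, on the numbers so far it sits level with compound 2 `CCCCC[C@H](C(C)C)C(c1ccc(O)c(OC)c1)c1ccc(O)c(OC)c1`, which gives 9600 nM; the change no change at the digits printed from compound 2 to compound 3 (within the scatter) is within the scatter. Compound 1 `COc1cc(C(c2ccc(O)c(OC)c2)[C@@H](C)[C@H](C)CO)ccc1O` reaches only a limit of the assay, > 100000 nM, and does not yield a number (the limit of > 100000 nM in this assay, at which 1 of the 3 values shown sits).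

The next compound, compound 4 `COc1cc(C(c2ccc(O)c(OC)c2)[C@H](C)[C@H](C)CO)ccc1O`, differs from compound 3 by 2-(hydroxymethyl)-1-methylpropyl in place of 1-isopropyl-3-methylbutyl on a saturated chain carbon bound to two aromatic carbons. The same 2-(hydroxymethyl)-1-methylpropyl group stands in compound 1, and the step of an at least 10-fold lower number from compound 1 to compound 3 (1.01 log units; beyond the scatter) ran the other way across this very exchange; the parallel step an at least 10-fold lower number from compound 1 to compound 2 (1.01 log units; beyond the scatter) was of the same size. Both were large, and both started from a value that was itself only a limit, so their true size may be greater than the figures show.

The step from compound 3 to compound 4 is therefore expected to reverse that change: a large rise in the number, a 10-fold higher number from compound 3 to compound 4 (1.02 log units; beyond the scatter), most probably running past the upper limit of the assay. Compound 4 is thus estimated at 100000 nM, within a range of 30000 nM to 300000 nM, with a fair chance that only a limit and no number is reported.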

Compound 4, half-maximal inhibitory concentration: > 100000 nM
Compound 4: only a limit was reported; the forecaster's own chance of this, stated with the estimate: 70%; the middle value lies on the limit itself.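

In this assay compound 4 also gives only a limit, > 100000 nM, and it is not alone there: the limit of > 100000 nM in this assay, at which 2 of the 4 values shown sit.

On the saturated chain carbon bound to two aromatic carbons, the exchange now reads in the direction of entry of 2-(hydroxymethyl)-1-methylpropyl, with an at least 10-fold higher number from compound 3 to compound 4 (1.01 log units; beyond the scatter) and an at least 10-fold higher number from compound 2 to compound 4 (1.01 log units; beyond the scatter), so the large step no longer rests on compound 1 alone. The step between the two compounds carrying this group cannot be read, but neither drawn configuration at the differing stereocentre gives a number in this assay: the fact that compounds 1 and 4 differ only in the configuration as drawn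

Going by these compounds, how far either compound lies past the limit stays open, and so does any difference between the two configurations. The entering group also differs from the leaving groups in both its carbon count and its hydroxyl, so these two changes remain unseparated here; a 2-(methoxymethyl)-1-methylpropyl group, or a 1-isopropylhexyl chain ending in a hydroxyl, would bear on that question.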